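Tert-butyl in place of thiophen-3-yl on the shared core

A few compounds are considered here, and "the series" means these few. Any claim that something is new, unique, unknown or untested is made for them only; others in the source may bear on it.

Compound 1 `O=C(O)c1cccc(Cc2c(-c3cccc(Cl)c3)nn3cc(Cl)ccc23)n1` sets the starting point: in a functional assay on cells for antagonist activity at prostaglandin E2 receptor EP1 subtype (Rattus norvegicus), read by fluorescence and calcium flux, with a stated time of 60 s (on this read-out higher numbers stand for weaker inhibition and lower numbers for stronger inhibition), compound 1 gives 480 nM. Compound 2 `O=C(O)c1cccc(Cc2c(-c3ccsc3)nn3cc(Cl)ccc23)n1` keeps the shared core and carries thiophen-3-yl where compound 1 carries 3-chlorophenyl; in this assay compound 2 gives 110 nM. That change is the single measured step, a 4.4-fold lower number from compound 1 to compound 2 (0.64 log units; beyond the scatter), and it leaves compound 2 with the lowest of the two numbers shown, compound 1 being its only neighbour.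

Compound 3 `CC(C)(C)c1nn2cc(Cl)ccc2c1Cc1cccc(C(=O)O)n1` is not yet measured. It differs from compound 2 in one place: tert-butyl in place of thiophen-3-yl on an aromatic carbon. Going by the values given here, the only measured step that bears on this position is a 4.4-fold lower number from compound 1 to compound 2 (0.64 log units; beyond the scatter), which swapped one aromatic ring for another and was modest but beyond the scatter. Among the compounds with values here, no measured step replaces an aromatic ring at this position with a group that has no ring, so the direction for compound 3 cannot be read from the series with confidence. On that thin footing the number for compound 3 is estimated at 400 nM, within 120 nM to 1500 nM, which would mean an expected step of a 3.6-fold higher number from compound 2 to compound 3 (0.56 log units; beyond the scatter).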

Compound 3, half-maximal inhibitory concentration: 48 nM
The estimate for compound 3 lay 8.3-fold (0.92 log units) above the measured number; measured number outside the range, below it.
By their numbers in this assay, from the lowest: compound 3; then compound 2; then compound 1.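

In this assay, this position on an aromatic carbon of the five-membered ring does not depend on an aromatic ring: tert-butyl, which has no ring, gives a 2.3-fold lower number from compound 2 to compound 3 (0.36 log units; beyond the scatter) in the direction of stronger inhibition. Going by these compounds alone, compounds 1 and 2 could show only one aromatic ring against another, whereas this change shows that removing the ring altogether is compatible with the lowest number. Taken against the first ring, the same replacement gives a 10-fold lower number from compound 1 to compound 3 (1.00 log units; beyond the scatter) and places tert-butyl ahead of both 3-chlorophenyl and thiophen-3-yl, with no measurement available here to explain that order.

The compounds shown leave open whether the gain is particular to tert-butyl or extends to other carbon groups with no ring, such as isopropyl, a longer chain such as n-butyl, or a saturated ring such as cyclohexyl. They also leave open how this position responds to a group that carries a heteroatom, such as an amine or a methoxy group, since tert-butyl is made up of carbon alone.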